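A few compounds are considered here, and "the series" means these few. Any claim that something is new, unique, unknown or untested is made for them only; others in the source may bear on it.

Compound 3 `CN(C)c1cc2[nH]c(C3CCCCC3)nc2cc1NC(=O)c1ccc(C(C)(C)C)cc1` stands at a limit in an ADME assay on Vero cells (Chlorocebus sabaeus) for cytotoxicity, read by resazurin assay, with a stated time of 3 days (a higher number here means a weaker inhibitor, a lower number a stronger inhibitor), where it gives > 100 ug/mL. Compound 1 `CN(C)c1cc2[nH]c(C3CCCCC3)nc2cc1NC(=O)c1ccc(Br)cc1` gives > 100 ug/mL, a limit. Compound 2 `CCCCOC(=O)Nc1cc2nc(C3CCCCC3)[nH]c2cc1N(C)C` gives > 100 ug/mL, also a limit. In short, (the limit of > 100 ug/mL in this assay, at which 3 of the 3 values shown sit). Compound 4 `CCCCCC(=O)Nc1cc2nc(C3CCCCC3)[nH]c2cc1N(C)C` differs from compound 3 by pentyl in place of 4-(tert-butyl)phenyl on a carbonyl carbon. The measured steps that bear on this change are a step that the two limits leave unreadable from compound 1 to compound 3 and a step that the two limits leave unreadable from compound 2 to compound 3, and the step that the two limits leave unreadable from compound 1 to compound 2 likewise gives no size. With every value around it a limit, no direction beyond the scatter can be read, so compound 4 is expected to sit near 120 ug/mL, within 60 ug/mL to 250 ug/mL. The step that the limit leaves unreadable from compound 3 to compound 4 is therefore expected to be small.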

Compound 4, half-maximal inhibitory concentration: > 100 ug/mL
Compound 4: only a limit was reported; the forecaster's own chance of this, stated with the estimate: 75%; the middle value lies beyond the limit too.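

The steps from compound 1, compound 2 and compound 3 to compound 4 cannot be read in this assay: the limit of > 100 ug/mL in this assay, at which 4 of the 4 values shown sit. Going by these compounds, whether these compounds differ from one another in this assay stays open.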